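The compounds below may be only part of what the source reports. "The series", "measured", "known", "first", "only" and "open" are said of these compounds alone.

Compound 1 `COc1cc(-c2cc(/C=C/C(=O)c3ccc(N)cc3)[nH]n2)cc(OC)c1OC` and compound 2 `COc1ccc(-c2cc(/C=C/C(=O)c3ccc(N)cc3)[nH]n2)cc1OC` share one core, while compound 3 `COc1cc(C(=O)/C=C/c2cc(-c3cc(OC)c(OC)c(OC)c3)n[nH]2)cc(OC)c1OC` and compound 4 `COc1ccc(-c2cc(/C=C/C(=O)c3cc(OC)c(OC)c(OC)c3)[nH]n2)cc1OC` share another; the difference between the two cores is not broken down here. In a functional assay on BT-549 cells (Homo sapiens) for inhibition, read by sulforhodamine B assay, with a stated time of 48 h (on this read-out higher numbers stand for weaker inhibition of growth and lower numbers for stronger inhibition of growth), compound 1 gives 1380 nM, and compound 2 gives 1500 nM. The change from compound 1 to compound 2 is hydrogen in place of methoxy on an aromatic carbon, and the step it made is a 1.1-fold higher number from compound 1 to compound 2 (0.04 log units; within the scatter). In this assay compound 3 gives 1570 nM. Compound 4 carries the same change, (hydrogen in place of methoxy on an aromatic carbon), made on the core of compound 3. A step of the same small size is expected, a 1.1-fold higher number from compound 3 to compound 4 (0.03 log units; within the scatter), because a 1.1-fold higher number from compound 1 to compound 2 (0.04 log units; within the scatter) stayed within the scatter. On that basis compound 4 is estimated at 1700 nM, with a range from 900 nM to 3300 nM.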

Compound 4, concentration for 50% growth inhibition: 1360 nM
Compound 4: middle estimate off by 1.3-fold (0.10 log units), on the high side; the measured number falls inside the stated range.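

In this assay, putting hydrogen in place of methoxy on the core of compound 3 gives a 1.2-fold lower number from compound 3 to compound 4 (0.06 log units; within the scatter), so on this core too the change stays inside the usual scatter. Set beside the earlier step, the two cores agree: the same change on two cores in this assay, a 1.1-fold higher number (0.04 log units; within the scatter) from compound 1 to compound 2 and a 1.2-fold lower number (0.06 log units; within the scatter) from compound 3 to compound 4, 1.3-fold (0.10 log units) apart, within the scatter of two such steps. This shows that, in this one assay, the change carries between these two cores without a step that can be read; it does not show that the same would hold on any other core, and two small steps make no rule for the wider series.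

The compounds shown leave open what happens when the methoxy gives way to something other than hydrogen, such as a hydroxy group, a chlorine atom or a carboxylic acid.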